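Methyl to methoxy on the carbamoyl aryl ring

The compounds below may be only part of what the source reports. "The series", "measured", "known", "first", "only" and "open" are said of these compounds alone.

Measured compounds:
compound 1 `O=C(CCC(=O)OCCCCCCSc1ccc([N+](=O)[O-])c2nonc12)Nc1ccccc1` 2490 nM
compound 2 `O=C(CCC(=O)OCCCCCCSc1ccc([N+](=O)[O-])c2nonc12)Nc1ccccc1F` 840 nM
compound 3 `Cc1ccccc1NC(=O)CCC(=O)OCCCCCCSc1ccc([N+](=O)[O-])c2nonc12` 1410 nM

In an ADME assay on HUVEC cells (Homo sapiens) for cytotoxicity, read by MTT assay, with a stated time of 72 h (on this read-out higher numbers stand for weaker inhibition and lower numbers for stronger inhibition), compound 3 gives 1410 nM, the second highest of the three numbers. Its nearest neighbour is compound 2 (a 1.7-fold higher number from compound 2 to compound 3 (0.22 log units; within the scatter)) and its furthest is compound 1 (a 1.8-fold lower number from compound 1 to compound 3 (0.25 log units; within the scatter)); both gaps sit within the scatter, so compound 3 cannot be placed above or below either of them.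

Compound 4 `COc1ccccc1NC(=O)CCC(=O)OCCCCCCSc1ccc([N+](=O)[O-])c2nonc12` is the next member. It differs from compound 3 in one place: methoxy in place of methyl on an aromatic carbon. Going by the values given here, the only steps that bear on this position are the small ones already seen there. The move from hydrogen to methyl (a 1.8-fold lower number from compound 1 to compound 3 (0.25 log units; within the scatter)) and from fluoro to methyl (a 1.7-fold higher number from compound 2 to compound 3 (0.22 log units; within the scatter)) each stayed within the scatter; only the move from hydrogen to fluoro (a 3.0-fold lower number from compound 1 to compound 2 (0.47 log units; beyond the scatter)) went beyond it, and that was modest. Among the compounds with values here, no methoxy at this position has been measured, so there is no direct precedent for the entering group.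

On this basis no step beyond the scatter is expected for compound 4 in this assay, with a 1.0-fold lower number from compound 3 to compound 4 (0.00 log units; within the scatter) as the expected movement. The estimate for compound 4 is 1400 nM, within 600 nM to 3200 nM.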

Compound 4, half-maximal inhibitory concentration: 1610 nM
Compound 4: the middle estimate sits 1.2-fold (0.06 log units) below what was measured, within the range that was stated.
By their numbers in this assay, from the lowest: compounds 2, 3, 4 and 1 (each within the scatter of the next, the first and the last beyond it).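

With methoxy, the position now holds a group that brings an oxygen and a hydrogen-bond acceptor, and in this assay this exchange on the aromatic carbon ortho to a large group gives only a small step (a 1.1-fold higher number from compound 3 to compound 4 (0.06 log units; within the scatter)). Compound 4 also cannot be separated from the other two analogues, the steps being (a 1.9-fold higher number from compound 2 to compound 4 (0.28 log units; within the scatter)) and (a 1.5-fold lower number from compound 1 to compound 4 (0.19 log units; within the scatter)), so in these compounds the added acceptor does not show up as a readable change, and the one gap beyond the scatter remains the step from hydrogen to fluoro (a 3.0-fold lower number from compound 1 to compound 2 (0.47 log units; beyond the scatter)). Nothing alongside these values bears on the result.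

The compounds shown leave open whether this position tolerates groups of another kind, such as an amine or a carboxylic acid, or a longer group such as ethoxy, to the same extent as methyl, fluoro and methoxy. They also leave open whether a methoxy placed elsewhere on the aryl ring, or a second methoxy, would stay within the same narrow band of values.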